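The source may report more compounds than this note shows. Statements on the series, on what has been measured and on what is new or still open speak of the compounds shown alone.

Measured in a functional assay on WiDr cells (Homo sapiens) for inhibition, read by sulforhodamine B assay, with a stated time of 48 h (a lower number here means a stronger inhibitor of growth, a higher number a weaker inhibitor of growth), so far:
- Compound 1 `CCOC(=[Se])Nc1ccc2c(C)cc(=O)oc2c1` gives > 100000 nM (a limit, not a number)
- Compound 2 `CCCCOC(=[Se])Nc1ccc2c(C)cc(=O)oc2c1` gives "nd(insoluble)" (no result reported)
- Compound 3 `Cc1cc(=O)oc2cc(NC(=[Se])Nc3ccccc3)ccc12` gives 34000 nM

Within the data shown here, compound 3 holds the only actual number here. Compound 4 `Cc1cc(=O)oc2cc(NC(=[Se])Nc3ccc(Br)cc3)ccc12` differs from compound 3 in a single place, where phenyl becomes 4-bromophenyl: bromo in place of hydrogen on an aromatic carbon and nothing else changes.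

Among the measured compounds shown here, only one measured step is available: an at least 2.9-fold lower number from compound 1 to compound 3 (0.46 log units; beyond the scatter) with anilino replacing ethoxy. That step shows that compound 3 gives a number in this assay but says nothing direct about a substituent on the phenyl ring. For the measured compounds named here, no measured pair tests bromo or any other group at that place, so the data set neither a size nor a direction for this change. The central expectation is therefore no step beyond the scatter, with real uncertainty on both sides. The estimated change is a 1.4-fold lower number from compound 3 to compound 4 (0.13 log units; within the scatter) and should be read as tentative. For compound 4 the expected value is 25000 nM with an estimated range from 6000 nM to 90000 nM in this measurement.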

Compound 4, concentration for 50% growth inhibition: 3500 nM
Estimate against measurement, compound 4: 7.1-fold (0.85 log units) above, and the stated range ends above it.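

In this assay, the change from phenyl to 4-bromophenyl gives a 9.7-fold lower number from compound 3 to compound 4 (0.99 log units; beyond the scatter), so this place on the ring is not silent: one added bromine atom clearly shifts growth inhibition. Among these compounds, this is the first step with a real number at both ends, whereas the earlier step, an at least 2.9-fold lower number from compound 1 to compound 3 (0.46 log units; beyond the scatter), starts from a limit and gives only a minimum size. Compound 1 stands at a limit, not a number: the limit of > 100000 nM in this assay, at which 1 of the 4 values shown sits.

On these data alone, whether this shift belongs to bromo itself or would appear with other groups stays open, and chloro, methoxy or an amine on the same aromatic carbon would test that. A single group at a single place also cannot show how other places on the phenyl ring behave, or why the number fell.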